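Methionine-type side chain on a second purine core

The source may hold more compounds than are shown below. What is called first, only, known or untested is meant among the compounds shown, and "the series" means these compounds.

Compound 1 `CSCC[C@H](NC(=O)CN(c1nc(Cl)nc2[nH]cnc12)C1CC1)C(=O)OCc1ccccc1` gives 17.6% in a functional assay on the whole organism (Tail, strain ICR) with Mus musculus as the target, in the tail flick test, with a stated time of 150 min, at a dose of 25 umol/kg by the oral route; a lower number here means a weaker effect, a higher number a stronger effect of the compound at the dose given.
Compound 2 `CC(C)C[C@H](NC(=O)CN(c1nc(Cl)nc2[nH]cnc12)C1CC1)C(=O)OCc1ccccc1` gives 5.26% in this assay.
Compound 3 `CC(C)C[C@H](NC(=O)CN(c1ncnc2c1ncn2C1CCCCO1)C1CC1)C(=O)OCc1ccccc1` gives 6.47% in this assay.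

Compound 1 and compound 2 share a core and differ in one place: (methylsulfanyl)methyl in place of isopropyl on a saturated chain carbon, two bonds along the chain from an amide-type nitrogen and a carbonyl carbon. That change made a step of a number 12.3 percentage points higher from compound 2 to compound 1 (beyond the scatter). Compound 3 carries a different core; the difference between the two cores is not broken down here. Compound 3 and compound 2 lie within the scatter of each other, while compound 3 sits well under compound 1.

Compound 4 `CSCC[C@H](NC(=O)CN(c1ncnc2c1ncn2C1CCCCO1)C1CC1)C(=O)OCc1ccccc1` is not yet measured. It stands to compound 3 as compound 1 stands to compound 2: (methylsulfanyl)methyl in place of isopropyl on a saturated chain carbon, two bonds along the chain from an amide-type nitrogen and a carbonyl carbon. The place line is the same word for word, so this is the same kind of change on the other core. Among the compounds with values here, because compound 3 starts from 6.47% and the one earlier example of this change gave a number 12.3 percentage points higher from compound 2 to compound 1 (beyond the scatter), the step from compound 3 to compound 4 is expected to be about a number 11.5 percentage points higher from compound 3 to compound 4 (beyond the scatter), though a single precedent on another core carries real uncertainty. Compound 4 is therefore estimated at 18%, between 6% and 32%.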

Compound 4, a percentage reported as activity, at one dose (the size of the read-out at that dose, not a potency): 17.5%
The estimate for compound 4 lay 0.5 percentage points above the measured number; the measured number falls inside the stated range.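

On the second core, (methylsulfanyl)methyl in place of isopropyl gave a number 11 percentage points higher from compound 3 to compound 4 (beyond the scatter) in this assay. Set beside the earlier case, the change carried over from one core to the other with a step of much the same size: the same change on two cores in this assay, a number 12.3 percentage points higher (beyond the scatter) from compound 2 to compound 1 and a number 11 percentage points higher (beyond the scatter) from compound 3 to compound 4, 1.3 percentage points apart, within the scatter of two such steps This shows that the gain held on both cores shown, at one dose and one time point, but it does not show that the step would hold on any further core, and single-dose read-outs say nothing about potency.

The compounds shown leave open whether a longer chain, or an amine, at this place on the saturated chain carbon would give a step of similar size. They also leave open whether the step would survive with a carboxylic acid in place of the benzyl ester, and how much the difference between the two cores contributes on its own.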